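The source may report more compounds than this note shows. Statements on the series, on what has been measured and on what is new or still open speak of the compounds shown alone.

Measured compounds:
compound 1 `CSc1ccc(COCC#CC(O)c2ccc(F)cc2)cc1`, 12000 nM
compound 2 `COc1ccc(C(O)C#CCOCc2ccc(SC)cc2)c(OC)c1OC`, 72000 nM

Among the measured compounds shown here, in an assay on isolated protein for inhibition of Polyunsaturated fatty acid 5-lipoxygenase (Homo sapiens) (on this read-out higher numbers stand for weaker inhibition and lower numbers for stronger inhibition), compound 1 gives 12000 nM, the lowest of the two numbers known so far. Compound 2 gives 72000 nM in this assay, a gap beyond the scatter. Compound 3 `CSc1ccc(COCC#CC(O)c2ccc(C(C)C)cc2)cc1` differs from compound 1 by isopropyl in place of fluoro on an aromatic carbon. For the measured compounds named here, no step between measured compounds shows what this change does, so the expectation rests on compound 1 alone. For compound 3 a modest step toward stronger inhibition is expected, a 2.0-fold lower number from compound 1 to compound 3 (0.30 log units; within the scatter). The estimate for compound 3 in this assay is 6000 nM, with a range from 1500 nM to 25000 nM.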

Compound 3, half-maximal inhibitory concentration: 8000 nM
The estimate for compound 3 lay 1.3-fold (0.12 log units) below the measured number; the measured number falls inside the stated range.
By their numbers in this assay, from the lowest: compounds 3 and 1 (each within the scatter of the next); then compound 2.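

In this assay, the aromatic carbon para to a large group accepts isopropyl in place of fluoro with a 1.5-fold lower number from compound 1 to compound 3 (0.18 log units; within the scatter), so this exchange of one fluorine for three carbon atoms leaves compound 3 and compound 1 indistinguishable on this read-out. The earlier compounds shown here gave no view of this change. No measured property of these groups bears on the result.

On these data alone, whether an amine or a carboxylic acid at this position would move the number beyond the scatter stays open. So does whether a longer chain would.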